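Indole Substituent Swaps on a Shared Diphenylmethylpiperazine Core

The compounds below may be only part of what the source reports. "The series", "measured", "known", "first", "only" and "open" are said of these compounds alone.

Measured compounds:
Compound 1 `Cc1cccc2c1ccn2CCCCN1CCN(C(c2ccccc2)c2ccccc2)CC1` gives 5300 nM in an assay on RPMI-8226 cells for antagonist activity at P2X purinoceptor 7 (Homo sapiens), read by calcium flux; on this read-out lower numbers stand for stronger inhibition and higher numbers for weaker inhibition.
Compound 2 `Cc1ccc2ccn(CCCCN3CCN(C(c4ccccc4)c4ccccc4)CC3)c2c1` gives 6500 nM in this assay.
Compound 3 `N#Cc1ccc2c(ccn2CCCCN2CCN(C(c3ccccc3)c3ccccc3)CC2)c1` gives 3800 nM in this assay.

The three measured compounds share one core and differ only in the group on the saturated chain carbon four bonds along the chain from the amine nitrogen in a ring. Their numbers sit close together: the steps of a 1.2-fold higher number from compound 1 to compound 2 (0.09 log units; within the scatter), a 1.4-fold lower number from compound 1 to compound 3 (0.14 log units; within the scatter) and a 1.7-fold lower number from compound 2 to compound 3 (0.23 log units; within the scatter) all lie within the scatter, so compound 3 cannot be set apart from compound 1 or compound 2 on these data.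

Compound 4 `Fc1cc2ccn(CCCCN3CCN(C(c4ccccc4)c4ccccc4)CC3)c2cc1F` carries the change (a group of 11 heavy atoms (8 carbon, 1 nitrogen, 2 fluorine; one five-membered aromatic ring with 1 hetero atom, one six-membered aromatic ring of carbon only) in place of a group of 11 heavy atoms (9 carbon, 2 nitrogen; one five-membered aromatic ring with 1 hetero atom, one six-membered aromatic ring of carbon only), on a saturated chain carbon, four bonds along the chain from an amine nitrogen in a ring). All three measured steps sit at the same place and bear on it, and none of them left the scatter. The step of a 1.2-fold higher number from compound 3 to compound 4 (0.07 log units; within the scatter) is therefore expected to stay within the scatter, with no clear direction. Compound 4 is estimated to give 4500 nM in this assay, within a range from 2000 nM to 10000 nM.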

Compound 4, half-maximal inhibitory concentration: 130 nM
For compound 4 the middle estimate is 35-fold (1.54 log units) above the measured one; the whole stated range lies above it.
By their numbers in this assay, from the lowest: compound 4; then compounds 3, 1 and 2 (each within the scatter of the next).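

Going by these compounds alone, at this place on the saturated chain carbon, the fluorine-bearing group in place of 5-cyano-1H-indol-1-yl gives the first step beyond the scatter (a 29-fold lower number from compound 3 to compound 4 (1.47 log units; beyond the scatter)). The steps (a 50-fold lower number from compound 2 to compound 4 (1.70 log units; beyond the scatter)) and (a 41-fold lower number from compound 1 to compound 4 (1.61 log units; beyond the scatter)) are of like size, so in this assay compound 4 stands apart from all three others, and this position proves responsive to the group it carries. Nothing shown accounts for the gain. On these data alone, whether it belongs to fluorine itself stays open, and so does whether chlorine or a methoxy group in its place would keep it.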